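Swapping the heteroaryl ketone of compound 2

The source may report more compounds than this note shows. Statements on the series, on what has been measured and on what is new or still open speak of the compounds shown alone.

Among the compounds with values here, compound 2 `CCCCCCCC/C=C\CCCCCCC(=O)c1nc2ccccc2o1` gives the highest of the two numbers so far: in an assay on isolated protein for inhibition of Fatty-acid amide hydrolase 1 (Homo sapiens) (on this read-out lower numbers stand for stronger inhibition and higher numbers for weaker inhibition), compound 2 gives 370 nM, while compound 1 `CCCCCCCC/C=C\CCCCCCC(=O)c1nc2ncccc2o1` gives 2.3 nM. Within the data shown here, the only step seen, a 160-fold higher number from compound 1 to compound 2 (2.21 log units; beyond the scatter), shows that exchanging the heteroaryl on the carbonyl carbon can move this read-out a great deal. Compound 3 `CCCCCCCC/C=C\CCCCCCC(=O)c1nccn1C` carries 1-methyl-1H-imidazol-2-yl in place of 1,3-benzoxazol-2-yl on a carbonyl carbon. Among the measured compounds shown here, no measured step covers this exchange, so the direction is uncertain; a step of moderate size is expected for compound 3, judged against compound 2, as a 2.7-fold higher number from compound 2 to compound 3 (0.43 log units; beyond the scatter). Compound 3 is expected to give about 1000 nM, between 200 nM and 5000 nM.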

Compound 3, inhibition constant: > 100000 nM
Compound 3 gave a limit, no number; the forecaster's own chance of this, stated with the estimate: 5%; middle value at least 100-fold (2.00 log units) away from the limit.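

Compound 3 gives only a limit, not a number, in this assay: the limit of > 100000 nM in this assay, at which 1 of the 3 values shown sits. On this carbonyl carbon, 1-methyl-1H-imidazol-2-yl in place of 1,3-benzoxazol-2-yl gives an at least 270-fold higher number from compound 2 to compound 3 (2.43 log units; beyond the scatter), and the comparison with the most strongly inhibiting compound gives an at least 43000-fold higher number from compound 1 to compound 3 (4.63 log units; beyond the scatter). The earlier pair showed a large shift between two measurable numbers, whereas this exchange takes the read-out to the limit of the assay.

As far as these compounds go, the exchange removes the six-membered ring and brings in the methyl together, so their separate shares remain open. From the compounds shown here alone, how an unmethylated 1H-imidazol-2-yl or a 1,3-oxazol-2-yl group would read here also remains open.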